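Swapping chloro for fluoro on a shared quinoline-free core

This account rests on a few compounds, and the source may have more. Where it says the series, first, only, none or still open, it means among the compounds named here.

Measured compounds:
Compound 1, `CCC(=O)NC(c1ccco1)c1cc(Cl)c2cccnc2c1O`, 1000 nM
Compound 2, `CC(=O)NC(c1ccco1)c1cc(Cl)c2cccnc2c1O`, 3000 nM

Among the measured compounds shown here, in an assay for inhibition of Polyunsaturated fatty acid lipoxygenase ALOX12 (Homo sapiens), read by spectrophotometry (on this read-out higher numbers stand for weaker inhibition and lower numbers for stronger inhibition), compound 2 gives 3000 nM, the higher of the two numbers seen so far, and the only neighbour is compound 1 at 1000 nM, with a 3.0-fold higher number from compound 1 to compound 2 (0.48 log units; beyond the scatter). That one step concerns the chain attached to the amide carbonyl, not the halogen on the ring.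

Compound 3, `CC(=O)NC(c1ccco1)c1cc(F)c2cccnc2c1O`, has not yet been measured. It differs from compound 2 by fluoro in place of chloro on an aromatic carbon. For the measured compounds named here, no measured pair changes the halogen, so the earlier step gives no direct guide for this change. Without a comparable step, the expectation for compound 3 in this assay is a change no larger than the scatter, estimated as no change at the digits printed from compound 2 to compound 3 (within the scatter). Compound 3 is therefore expected to give about 3000 nM, within a range from 1000 nM to 9000 nM.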

Compound 3, half-maximal inhibitory concentration: 5000 nM
Beside the measured number, compound 3's estimate is 1.7-fold (0.22 log units) below it; measured number inside the range.
By their numbers in this assay, from the lowest: compound 1; then compounds 2 and 3 (each within the scatter of the next).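

In this assay, putting fluoro in place of chloro on the aromatic carbon para to a hydroxy group gives a 1.7-fold higher number from compound 2 to compound 3 (0.22 log units; within the scatter), so these two halogens cannot be told apart at this position in this pair. The only other step shown, at the chain on the amide carbonyl, is a 3.0-fold higher number from compound 1 to compound 2 (0.48 log units; beyond the scatter) and lies beyond the scatter, whereas this first reading of the halogen position does not. No measurement shown bears on why the swap of halogens behaves this way.

From the compounds shown here alone, what a bromo group, a nitrile or a plain hydrogen would do at this position stays open. So does whether fluoro in place of chloro would read the same on the core of compound 1, which carries the longer chain on its amide carbonyl.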